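The source may hold more compounds than are shown below. What is called first, only, known or untested is meant among the compounds shown, and "the series" means these compounds.

Measured compounds:
compound 1, `Cc1noc(NS(=O)(=O)c2cccc3c(N(C)C)cccc23)c1[N+](=O)[O-]`, giving 17300 nM in an assay on VSM-A10 cells for antagonist activity at Endothelin-1 receptor (Rattus norvegicus); a lower number here means a stronger inhibitor, a higher number a weaker inhibitor
compound 2, `Cc1noc(NS(=O)(=O)c2cccc3ccccc23)c1C`, giving 20000 nM in this assay
compound 3, `CC(C)(C)c1cc(NS(=O)(=O)c2ccc(N)cc2)no1`, a limit only, > 32000 nM in this assay

Compound 2 holds the higher of the two plain numbers in this assay, but the nearest compound, compound 1, sits within the scatter of it, so no order between the two can be read. Compound 3 is known in this assay only as a limit, (the limit of > 32000 nM in this assay, at which 1 of the 3 values shown sits), and gives no number to compare.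

Compound 4, `Cc1noc(NS(=O)(=O)c2cccc3c(C(C)(C)O)cccc23)c1C`, is not yet measured. It differs from compound 2 in one place: 1-hydroxy-1-methylethyl in place of hydrogen on an aromatic carbon. For the measured compounds named here, no measured pair follows a change of this kind, so the expected size of the step rests only on the narrow spread among the numbers at hand. Compound 4 is expected to give about 15000 nM in this assay, somewhere between 5000 nM and 40000 nM. The expected step of a 1.3-fold lower number from compound 2 to compound 4 (0.12 log units; within the scatter) is small, and a result that stays within the scatter of compound 2 would be no surprise.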

Compound 4, half-maximal inhibitory concentration: 2890 nM
Beside the measured number, compound 4's estimate is 5.2-fold (0.72 log units) above it, and the stated range ends above it.
By their numbers in this assay, from the lowest: compound 4; then compounds 1 and 2 (each within the scatter of the next). At a limit, above all of these: compound 3.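

In this assay, 1-hydroxy-1-methylethyl in place of hydrogen on this aromatic carbon brings a 6.9-fold lower number from compound 2 to compound 4 (0.84 log units; beyond the scatter). It is the only step among the compounds shown that links two measured compounds. It shows that this carbon, on a six-membered aromatic ring that is part of a fused system of two rings, tolerates a branched group that carries a hydroxyl, and that the number in this assay responds to what stands there. Nothing measured among these compounds bears on why the number falls, so the step stands as an observation only.

From the compounds shown here alone, a single pair cannot separate the hydroxyl from the branched carbons around it, so it stays open whether tert-butyl, which keeps the carbons without the hydroxyl, or a plain hydroxyl on the same aromatic carbon would give a step of similar size. Also open, going by these compounds, is how a longer chain, an amine or a carboxylic acid would fare at this carbon, and whether the step would hold with other groups elsewhere on the core of compound 4.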